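The source may report more compounds than this note shows. Statements on the series, on what has been measured and on what is new or still open speak of the compounds shown alone.

Measured in an ADME assay on BaF3 cells (Mus musculus) for antiproliferative activity, read by CCK-8 assay, with a stated time of 72 h; on this read-out higher numbers stand for weaker inhibition of growth and lower numbers for stronger inhibition of growth:

Compound 1 `CNC(=O)CCSc1ccc2c(/C=C/c3ccccn3)n[nH]c2c1`: > 10000 nM, which is a limit of the assay and not a number.
Compound 2 `O=C(CCSc1ccc2c(/C=C/c3ccccn3)n[nH]c2c1)Nc1cccc(C(F)(F)F)c1`: 2300 nM
Compound 3 `O=C(CCSc1ccc2c(/C=C/c3ccccn3)n[nH]c2c1)NCc1cccc(C(F)(F)F)c1`: 8030 nM

Compound 2, at 2300 nM, holds the lower of the two actual numbers, so it shows the strongest growth inhibition in this small set. Compound 4 `CN1CCN(Cc2ccc(NC(=O)CCSc3ccc4c(/C=C/c5ccccn5)n[nH]c4c3)cc2C(F)(F)F)CC1` has not yet been measured. It keeps all of compound 2 except that a (4-methylpiperazin-1-yl)methyl group takes the place of a hydrogen on an aromatic carbon, ortho to the trifluoromethyl group: (4-methylpiperazin-1-yl)methyl in place of hydrogen on an aromatic carbon.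

Going by the values given here, no measured step adds a group at that place, so the evidence is indirect. Changes to the group on the amide nitrogen have moved the number: a 3-(trifluoromethyl)phenyl group in place of methyl gave an at least 4.3-fold lower number from compound 1 to compound 2 (0.63 log units; beyond the scatter), and a 3-(trifluoromethyl)benzyl group in place of that phenyl gave a 3.5-fold higher number from compound 2 to compound 3 (0.54 log units; beyond the scatter). The other change gave an at least 1.2-fold lower number from compound 1 to compound 3 (0.09 log units; that floor lies within the scatter). These steps suggest that this end of the molecule matters, and a new group here is expected to shift the number by a comparable or somewhat larger amount, with a lower number more likely but not certain. The expected change is a 4.6-fold lower number from compound 2 to compound 4 (0.66 log units; beyond the scatter). The estimate for compound 4 is 500 nM, with an expected range from 60 nM to 3000 nM.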

Compound 4, concentration for 50% growth inhibition: 2480 nM
Beside the measured number, compound 4's estimate is 5.0-fold (0.70 log units) below it; low and high end bracket the measured number.
By their numbers in this assay, from the lowest: compounds 2 and 4 (each within the scatter of the next); then compound 3. At a limit, above all of these: compound 1.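

In this assay, putting (4-methylpiperazin-1-yl)methyl in place of hydrogen on this aromatic carbon, ortho to a trifluoromethyl group, gives a 1.1-fold higher number from compound 2 to compound 4 (0.03 log units; within the scatter), so compound 2 and compound 4 cannot be told apart on this read-out. The earlier steps shown here replaced the whole group on the amide nitrogen and showed that such swaps can move the number; this step shows that a much larger addition further out on the aromatic ring, 8 heavy atoms including a six-membered non-aromatic ring, can leave the number within the scatter. No measurement shown here offers an explanation for this result.

The compounds shown leave open whether a different group on this same carbon, such as a morpholine ring, a dimethylaminomethyl group or a carboxylic acid, would give a number beyond the scatter of compound 2. They also leave open whether (4-methylpiperazin-1-yl)methyl would behave the same way on the ring of compound 3, where a saturated chain carbon links that ring to the amide nitrogen.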